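Homologation step checked on a second core in the adenosine assay

This account rests on a few compounds, and the source may have more. Where it says the series, first, only, none or still open, it means among the compounds named here.

Compound 1 `CCOC(=O)C1=C(C)N(C)C(=O)NC1c1cccs1` — 1%
Compound 2 `CCCOC(=O)C1=C(C)N(C)C(=O)NC1c1cccs1` — 9%
Compound 3 `CCCC(=O)C1=C(C)NC(=O)NC1c1ccco1` — 1%

In an assay on membranes from CHO cells for displacement of a labelled ligand from adenosine receptor A1 (Homo sapiens), read by scintillation counting, with a stated time of 60 min, tested at 1 uM (on this read-out higher numbers stand for more inhibition at the one concentration tested (going by the name of the read-out) and lower numbers for less inhibition), compound 1 gives 1%. Compound 2 carries the change (methyl in place of hydrogen on a saturated chain carbon, two bonds along the chain from an oxygen next to a carbonyl group); in this assay compound 2 gives 9%, so the step is a number 8 percentage points higher from compound 1 to compound 2 (within the scatter). Compound 3 belongs to a different core; the difference between the two cores is not broken down here. In this assay compound 3 gives 1%.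

Compound 4 `CC1=C(C(=O)CC(C)C)C(c2ccco2)NC(=O)N1` has not been measured. It is made from compound 3 by methyl in place of hydrogen on a saturated chain carbon bound to two saturated chain carbons. This is the same kind of change as that from compound 1 to compound 2: in both a methyl enters in place of a hydrogen, but around the place the two differ, since in compound 2 the saturated chain carbon is two bonds along the chain from an oxygen next to a carbonyl group, whereas in compound 4 it is a saturated chain carbon bound to two saturated chain carbons.

Because the step of a number 8 percentage points higher from compound 1 to compound 2 (within the scatter) stayed within the scatter, compound 4 is expected to move only a little, estimated as a number 4 percentage points higher from compound 3 to compound 4 (within the scatter). The estimate for compound 4 in this assay is 5%, between -5% and 15%.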

Compound 4, a percentage reported as inhibition, at one concentration (the size of the read-out at that concentration, not a potency): 16%
Estimate against measurement, compound 4: 11 percentage points below; measured number outside the range, above it.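

In this assay, the methyl that turns propylcarbonyl into isobutylcarbonyl gives a number 15 percentage points higher from compound 3 to compound 4 (beyond the scatter). Set beside the earlier step on the other core, this result does not differ from it by more than two such steps would be expected to scatter: the same change on two cores in this assay, a number 8 percentage points higher (within the scatter) from compound 1 to compound 2 and a number 15 percentage points higher (beyond the scatter) from compound 3 to compound 4, 7 percentage points apart, within the scatter of two such steps. The two cores therefore give no sign that the change behaves differently from one to the other, but with a single pair on each core and the methyl entering a different chain in each pair, this does not show that the change carries over with a fixed size.

On these data alone, it remains open whether a longer chain or an amine in place of the isobutylcarbonyl group would take the number in this assay further up or back down. Also open is how the isobutylcarbonyl group itself would read on the core of compound 1, where only the ethyl and propyl chains are shown.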